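The compounds below may be only part of what the source reports. "The series", "measured", "known", "first", "only" and "open" are said of these compounds alone.

In an ADME assay on cells (Homo sapiens) for cytotoxicity, read by resazurin assay, with a stated time of 5 days (on this read-out higher numbers stand for lower toxicity in this test and lower numbers for higher toxicity in this test), compound 1 (`COc1ccc(Nc2nc(CS(=O)(=O)c3cccc(Cl)c3)nc3ccsc23)cc1`) gives 60000 nM as its reading. Compound 2 (`O=S(=O)(Cc1nc(-c2ccoc2)c2sccc2n1)c1cccc(Cl)c1`) shows > 50000 nM and that is a limit of the assay, not a number. Compound 3 (`O=S(=O)(Cc1nc(-c2cccs2)c2sccc2n1)c1cccc(Cl)c1`) carries thiophen-2-yl in place of furan-3-yl on an aromatic carbon. Within the data shown here, the one measured step that bears on this swap, made on the same carbon (a step that the limit leaves unreadable from compound 1 to compound 2), has no readable size, so it offers no size to carry over. The expected step in this assay is none beyond the scatter, in either direction (a number no higher from compound 2 to compound 3 (the limit leaves the size open)). Compound 3 is estimated at 50000 nM (expected range 20000 nM to 100000 nM).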

Compound 3, half-maximal cytotoxic concentration: > 50000 nM
Compound 3 ended at the assay's limit; the forecaster's own chance of this, stated with the estimate: 55%; the middle value lies on the limit itself.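

No step can be read from compound 2 to compound 3 or from compound 1 to compound 3, because the readings of compound 2 and compound 3 are limits, not numbers: the limit of > 50000 nM in this assay, at which 2 of the 3 values shown sit.

The compounds shown leave open how far apart the true readings of all three compounds lie in this assay.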